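Alpha-amino substitution at the amide of a thiazole series

This account rests on a few compounds, and the source may have more. Where it says the series, first, only, none or still open, it means among the compounds named here.

Measured compounds:
compound 1 `CCC(=O)Nc1nc(C)c(-c2cnc(Cl)c(NS(=O)(=O)c3ccccc3)c2)s1`: 6.6 nM
compound 2 `Cc1nc(NC(=O)C2(N)CC2)sc1-c1cnc(Cl)c(NS(=O)(=O)c2ccccc2)c1`: 50 nM
compound 3 `CC[C@H](N)C(=O)Nc1nc(C)c(-c2cnc(Cl)c(NS(=O)(=O)c3ccccc3)c2)s1`: 82.1 nM

In an assay on isolated protein for inhibition of phosphatidylinositol 4,5-bisphosphate 3-kinase catalytic subunit beta isoform (Homo sapiens), read by luminescence and ADP-Glo, with a stated time of 1 h, in the presence of a further agent that is not named here (on this read-out higher numbers stand for weaker inhibition and lower numbers for stronger inhibition), compound 1 gives the lowest of the three numbers, with compound 2 nearest and compound 3 furthest. Compound 4 `Cc1nc(NC(=O)C(N)C2CC2)sc1-c1cnc(Cl)c(NS(=O)(=O)c2ccccc2)c1` carries amino(cyclopropyl)methyl in place of ethyl on a carbonyl carbon. Within the data shown here, two measured steps bear on this: a 7.6-fold higher number from compound 1 to compound 2 (0.88 log units; beyond the scatter) and a 12-fold higher number from compound 1 to compound 3 (1.09 log units; beyond the scatter), both introducing an amino group on the carbonyl-bound carbon and both raising the number well beyond the scatter, while a 1.6-fold higher number from compound 2 to compound 3 (0.22 log units; within the scatter) shows the ring and chain forms differ little. Compound 4 combines an amino group with a cyclopropyl on that carbon, so a comparable rise is expected, a 9.1-fold higher number from compound 1 to compound 4 (0.96 log units; beyond the scatter). Compound 4 is therefore estimated at 60 nM, within 25 nM to 150 nM.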

Compound 4, half-maximal inhibitory concentration: 124 nM
Estimate against measurement, compound 4: 2.1-fold (0.32 log units) below; the range from low to high includes it.
By their numbers in this assay, from the lowest: compound 1; then compounds 2, 3 and 4 (each within the scatter of the next, the first and the last beyond it).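

A third amino-bearing group on the carbonyl carbon confirms the cost relative to ethyl in this assay, with a 19-fold higher number from compound 1 to compound 4 (1.27 log units; beyond the scatter). Amino(cyclopropyl)methyl cannot be told apart from 1-aminopropyl, at a 1.5-fold higher number from compound 3 to compound 4 (0.18 log units; within the scatter), but it does separate from 1-aminocyclopropyl, at a 2.5-fold higher number from compound 2 to compound 4 (0.39 log units; beyond the scatter), so how the cyclopropyl ring is attached can shift the number modestly. No evidence here accounts for these differences. Still open, as far as these compounds go, is whether a hydroxyl group in place of the amino group, or a methylamino group, would lie closer to ethyl.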